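The compounds below may be only part of what the source reports. "The series", "measured", "known", "first", "only" and "open" are said of these compounds alone.

Measured in a physicochemical assay for solubility, with a stated time of 3 days, at pH 2; a higher number here means a more soluble compound, a lower number a less soluble compound:

Compound 1, `NC(=O)c1ccc2[nH]c(-c3ccc(OCCC4CCCCN4Cc4ccccc4)cc3)nc2c1`: its value here is a limit of the assay, > 400000 nM.
Compound 2, `COc1ccc(CN2CCCCC2CCOc2ccc(-c3nc4cc(C(N)=O)ccc4[nH]3)cc2)cc1`: its value here is also a limit of the assay, > 400000 nM.
Compound 3, `NC(=O)c1ccc2[nH]c(-c3ccc(OCCC4CCN(Cc5ccccc5)CC4)cc3)nc2c1`: in this assay compound 3 gives 110000 nM.

Compound 1 and compound 2 differ by one change, (methoxy in place of hydrogen on an aromatic carbon). The step it made, a step that the two limits leave unreadable from compound 1 to compound 2, cannot be read because both compounds sit at the limit of > 400000 nM in this assay, at which 2 of the 3 values shown sit. Compound 3 carries the same atoms as compound 1 joined differently; the difference between the two cores is not broken down here.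

Compound 4, `COc1ccc(CN2CCC(CCOc3ccc(-c4nc5cc(C(N)=O)ccc5[nH]4)cc3)CC2)cc1`, has not yet been measured in this assay. It stands to compound 3 as compound 2 stands to compound 1, the change being (methoxy in place of hydrogen on an aromatic carbon). Since the earlier step is unreadable, the expected step from compound 3 to compound 4 is placed near zero, a 1.1-fold lower number from compound 3 to compound 4 (0.04 log units; within the scatter), with wide bounds. For compound 4 the estimated solubility in this assay is therefore 100000 nM, expected to lie between 35000 nM and 300000 nM.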

Compound 4, solubility: > 400000 nM
Compound 4: only a limit was reported; the forecaster's own chance of this, stated with the estimate: 10%; at least 4.0-fold (0.60 log units) between middle value and limit.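

In this assay, the change from phenyl to 4-methoxyphenyl on the core of compound 3 gives an at least 3.6-fold higher number from compound 3 to compound 4 (0.56 log units; beyond the scatter), so on this core the step can be read and points to a higher number. The value of compound 4, > 400000 nM, is a limit of the assay, so the step gives only a minimum size and not a true one. The same change on the core of compound 1 cannot be read, so the compounds do not show whether the step carries from one core to the other or is of similar size on both: the limit of > 400000 nM in this assay, at which 3 of the 4 values shown sit.

The compounds shown carry only hydrogen or methoxy at this place, so it stays open whether the higher number is particular to methoxy. An ethoxy group, a hydroxyl group or a chlorine atom on the same aromatic carbon would test this, ideally on a parent compound whose value lies clear of the limit.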